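A Furan-to-Hydroxypyridine Swap on a Thiazole Acetic Acid

The compounds below may be only part of what the source reports. "The series", "measured", "known", "first", "only" and "open" are said of these compounds alone.

Of the compounds shown here, two sharing a carboxymethyl-bearing core have been measured in an in vitro assay on HEK385-7 cells for displacement of a labelled ligand from prostaglandin D2 receptor 2 (Homo sapiens); on this read-out lower numbers stand for stronger inhibition and higher numbers for weaker inhibition. Compound 1, `O=C(O)Cc1sc(NC(=O)c2ccccc2)nc1-c1ccc(Cl)cc1`, gives 520 nM in this assay. Compound 2, `O=C(O)Cc1sc(C(c2ccc(F)cc2)c2ccc(F)cc2)nc1-c1ccco1`, gives 18 nM in this assay. Of the two numbers, compound 2 holds the lower one, and its gap to compound 1 lies beyond the usual scatter of repeated measurements, so compound 2 is the stronger binder of the pair.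

The next compound, compound 3, `O=C(O)Cc1sc(C(c2ccc(F)cc2)c2ccc(F)cc2)nc1-c1ccnc(O)c1`, has not yet been measured. It differs from compound 2 in one place: 2-hydroxypyridin-4-yl in place of furan-2-yl on an aromatic carbon. Among the compounds with values here, no comparable single change has been measured here, so there is no directly relevant step to lean on. With the rest of compound 2 unchanged, compound 3 is expected to stay in a similar range, and the step of a 2.2-fold higher number from compound 2 to compound 3 (0.35 log units; beyond the scatter) is estimated to be a modest weakening at most, possibly none beyond the scatter. Compound 3 is therefore estimated at 40 nM in this assay, with a plausible range from 10 nM to 160 nM.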

Compound 3, half-maximal inhibitory concentration: 68 nM
The estimate for compound 3 lay 1.7-fold (0.23 log units) below the measured number; the measured number falls inside the stated range.
By their numbers in this assay, from the lowest: compound 2; then compound 3; then compound 1.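

On the aromatic carbon next to the ring nitrogen, in this assay, replacing furan-2-yl with 2-hydroxypyridin-4-yl gives a 3.8-fold higher number from compound 2 to compound 3 (0.58 log units; beyond the scatter), the first single change measured here, which shows that this position responds to the group it carries, though only modestly in this instance. The step also shows that a larger six-membered aromatic ring bearing a hydrogen-bond donor can sit at this carbon without an extreme loss in the number, but this one swap changes ring size, hetero atom and hydroxyl group all at once, so it cannot divide the step among them. Nothing measured here explains the weakening, so its cause remains unknown.

Still open is which part of the new group accounts for the step: pyridin-4-yl without the hydroxyl would test the ring alone, while an amine or a methoxy group in place of the hydroxyl would test that substituent. Whether the same swap would give a similar step with a different group in place of the two 4-fluorophenyl rings also remains unanswered.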